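Aryl swap on the saturated ring carbon: compound 4

The source may report more compounds than this note shows. Statements on the series, on what has been measured and on what is new or still open speak of the compounds shown alone.

The three measured compounds share one core and differ mainly in the aryl group on a saturated ring carbon. In a functional assay, with a stated time of 20 min, tested at 10 uM (on this read-out lower numbers stand for a weaker effect and higher numbers for a stronger effect at the one concentration tested), compound 1 `COc1cc(/C=C/C(=O)C2=C(/C=C/c3ccc(O)c(OC)c3)NC(=O)NC2c2cccc([N+](=O)[O-])c2)ccc1O` gives 51.2%, compound 2 `COc1cc(/C=C/C(=O)C2=C(/C=C/c3ccc(O)c(OC)c3)NC(=O)NC2c2ccccc2Cl)ccc1O` gives 40%, and compound 3 `COc1cc(/C=C/C(=O)C2=C(/C=C/c3ccc(O)c(OC)c3)NC(=S)NC2c2ccc(C)cc2)ccc1O` gives 43.2%. For the measured compounds named here, compound 3 stands second highest of the three, within the scatter of both compound 2 and compound 1; it differs from those two in more than one place, so no single step to it is given. Compound 4 `COc1cc(/C=C/C(=O)C2=C(/C=C/c3ccc(O)c(OC)c3)NC(=S)NC2c2c(Cl)cccc2Cl)ccc1O` differs from compound 3 by 2,6-dichlorophenyl in place of 4-methylphenyl on a saturated ring carbon. Going by the values given here, the only measured step that exchanges the aryl group at that carbon is a number 11.2 percentage points lower from compound 1 to compound 2 (beyond the scatter), a modest loss. A small loss or none beyond the scatter is expected, a number 3.2 percentage points lower from compound 3 to compound 4 (within the scatter). Compound 4 is estimated at 40%, within 28% to 52%.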

Compound 4, a percentage reported as activity, at one concentration (the size of the read-out at that concentration, not a potency): 29%
For compound 4 the middle estimate is 11 percentage points above the measured one; low and high end bracket the measured number.
By their numbers in this assay, from the lowest: compound 4; then compounds 2, 3 and 1 (each within the scatter of the next, the first and the last beyond it).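

In this assay, 2,6-dichlorophenyl in place of 4-methylphenyl on the saturated ring carbon gives a number 14.2 percentage points lower from compound 3 to compound 4 (beyond the scatter). Alongside a number 11.2 percentage points lower from compound 1 to compound 2 (beyond the scatter), this makes a second pair in which an aryl exchange at this carbon moves the read-out beyond the scatter, and this pair carries sulfur where the earlier pair carries the carbonyl oxygen. No available evidence bears on the reason for this loss. This single pair cannot separate the effect of adding the two chlorine atoms from that of losing the methyl group. On these data alone, how a pyridyl or 4-aminophenyl group at this carbon would read remains open.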